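A few compounds are considered here, and "the series" means these few. Any claim that something is new, unique, unknown or untested is made for them only; others in the source may bear on it.

Of the compounds shown here, three built on one shared core have been measured in a functional assay on M21 cells (Homo sapiens) for antiproliferative activity, read by sulforhodamine B assay, with a stated time of 48 h; on this read-out higher numbers stand for weaker inhibition and lower numbers for stronger inhibition. Compound 1 `CCCC(=O)Nc1ccc(S(=O)(=O)Oc2ccccc2I)cc1` gives 9000 nM, compound 2 `CCNC(=O)Nc1ccc(S(=O)(=O)Oc2ccccc2I)cc1` gives 5600 nM, and compound 3 `O=C(NCCCCl)Nc1ccc(S(=O)(=O)Oc2ccccc2I)cc1` gives 4600 nM, the lowest of the three numbers, although every gap among them lies within the scatter: a 1.6-fold lower number from compound 1 to compound 2 (0.21 log units; within the scatter), a 2.0-fold lower number from compound 1 to compound 3 (0.29 log units; within the scatter), and a 1.2-fold lower number from compound 2 to compound 3 (0.09 log units; within the scatter). Compound 4 `O=C(Nc1ccc(S(=O)(=O)Oc2ccccc2I)cc1)NC1CC1` differs from compound 3 by cyclopropyl in place of 3-chloropropyl on an amide-type nitrogen. The nearest guide is the chain change between compound 2 and compound 3, which stayed within the scatter, as did the other two steps on this nitrogen side chain. No step beyond the scatter is therefore expected in this assay for compound 4, whose number is estimated at 4600 nM, between 2000 nM and 10000 nM, meaning no change at the digits printed from compound 3 to compound 4 (within the scatter).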

Compound 4, half-maximal inhibitory concentration: 11000 nM
For compound 4 the middle estimate is 2.4-fold (0.38 log units) below the measured one, and the stated range ends below it.
By their numbers in this assay, from the lowest: compounds 3, 2, 1 and 4 (each within the scatter of the next, the first and the last beyond it).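

In this assay this nitrogen side chain gives its first step beyond the scatter, a modest one, with cyclopropyl in place of 3-chloropropyl (a 2.4-fold higher number from compound 3 to compound 4 (0.38 log units; beyond the scatter)). Cyclopropyl in place of ethyl on the same nitrogen stays within the scatter (a 2.0-fold higher number from compound 2 to compound 4 (0.29 log units; within the scatter)), as does the remaining step (a 1.2-fold higher number from compound 1 to compound 4 (0.09 log units; within the scatter)). Nothing available explains this difference. The compounds shown leave open how a cyclobutyl ring, a butyl chain or a chain ending in an amine on this nitrogen would read in this assay.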